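Indazole pair with trifluoromethylphenyl: an isopropyl-to-ethoxy exchange

This account rests on a few compounds, and the source may have more. Where it says the series, first, only, none or still open, it means among the compounds named here.

Measured so far:
compound 1 `FC(F)c1ccccc1-c1ccc2[nH]ncc2c1` gives 2200 nM;
compound 2 `N#Cc1ccccc1-c1ccc2[nH]ncc2c1` gives 1290 nM;
compound 3 `CC(C)c1cc2[nH]ncc2cc1-c1ccccc1C(F)(F)F` gives 25400 nM.

All three numbers come from an assay on CHO-TREX cells for antagonist activity at transient receptor potential cation channel subfamily A member 1 (Homo sapiens), read by FLIPR and calcium flux, with a stated time of 10 min; a lower number here means a stronger inhibitor, a higher number a weaker inhibitor. Compound 3 stands highest of the three. Against compound 1 the step is a 1.7-fold lower number from compound 1 to compound 2 (0.23 log units; within the scatter), and the exchange involved there, cyano for difluoromethyl on the other ring, is the only single-point step among the measured compounds. Compound 3 differs from compound 1 and compound 2 in two places, so its gap to them cannot be attributed to either place alone.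

Compound 4 `CCOc1cc2[nH]ncc2cc1-c1ccccc1C(F)(F)F` is not yet measured. It differs from compound 3 in a single place: ethoxy in place of isopropyl on an aromatic carbon. Going by the values given here, no measured step concerns this position or this exchange, and the one step that exists, from compound 1 to compound 2, sits on the other ring and lies within the scatter. There is thus nothing in the data that points in a direction for the ethoxy. His expectation for compound 4 in this assay is therefore anchored on compound 3, with a wide range: the step is estimated as a 1.7-fold lower number from compound 3 to compound 4 (0.23 log units; within the scatter). For compound 4 the estimate is 15000 nM, within 4000 nM to 60000 nM.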

Compound 4, half-maximal inhibitory concentration: 39 nM
Beside the measured number, compound 4's estimate is 380-fold (2.59 log units) above it; the whole stated range lies above it.
By their numbers in this assay, from the lowest: compound 4; then compounds 2 and 1 (each within the scatter of the next); then compound 3.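

In this assay, going by these compounds alone, ethoxy in place of isopropyl on an aromatic carbon, ortho to a large group, gives a 650-fold lower number from compound 3 to compound 4 (2.81 log units; beyond the scatter) and so shows that this position, which no earlier step touched, can move the number far beyond the scatter through a single exchange. Isopropyl and ethoxy each hold 3 heavy atoms, but ethoxy has an oxygen in place of a carbon and brings 1 hydrogen-bond acceptor where isopropyl has 0, so a like count of heavy atoms at this position does not go with a like number in this assay. Nothing measured here gives a reason for the size of this step.

The compounds shown leave open whether the oxygen alone carries the change or the ethyl part also contributes, a question that methoxy, a longer chain such as propoxy, or an amine at the same position would bear on. They also leave open whether ethoxy gives a step of this size when cyano or difluoromethyl stands in place of trifluoromethyl on the other ring.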